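Cyclobutyl in place of pentyl: a step between limits

The source may report more compounds than this note shows. Statements on the series, on what has been measured and on what is new or still open speak of the compounds shown alone.

Compound 1 `CCCCCCN1CCC(C(=O)Nc2cc(Cl)c(N)cc2OC)CC1` — > 10 mg/kg. Compound 2 `COc1cc(N)c(Cl)cc1NC(=O)C1CCN(CC2CC2)CC1` — > 10 mg/kg. Compound 3 `CCCN1CCC(C(=O)Nc2cc(Cl)c(N)cc2OC)CC1` — > 10 mg/kg.

In a functional assay on the whole organism for antagonist activity, with Mus musculus as the target (on this read-out higher numbers stand for an effect only at larger amounts of compound and lower numbers for an effect already at smaller amounts), compound 1 gives > 10 mg/kg, a limit of the assay and not a number. Compound 2 likewise gives only a limit, > 10 mg/kg. Compound 3 also stands at a limit, > 10 mg/kg. All three sit at the limit of > 10 mg/kg in this assay, at which 3 of the 3 values shown sit, so the measured steps are unreadable: a step that the two limits leave unreadable from compound 1 to compound 2, a step that the two limits leave unreadable from compound 1 to compound 3 and a step that the two limits leave unreadable from compound 2 to compound 3 give no size. Compound 4 `COc1cc(N)c(Cl)cc1NC(=O)C1CCN(CC2CCC2)CC1` differs from compound 1 by cyclobutyl in place of pentyl on a saturated chain carbon bound to an amine nitrogen in a ring. The steps a step that the two limits leave unreadable from compound 1 to compound 2 and a step that the two limits leave unreadable from compound 2 to compound 3 at the same place bear on it but reveal no direction. Compound 4 is therefore expected to remain at the limit, with a step that the limit leaves unreadable from compound 1 to compound 4 estimated as no readable step, and an expected value of 15 mg/kg (range 8 mg/kg to 40 mg/kg).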

Compound 4, dose for half-maximal effect: > 10 mg/kg
Compound 4 ended at the assay's limit (the forecaster's own chance of this, stated with the estimate: 80%); the middle value lies beyond the limit too.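

Compound 4 stands at a limit of the assay and not at a number, as do compound 1, compound 2 and compound 3, so none of its steps to them can be read: the limit of > 10 mg/kg in this assay, at which 4 of the 4 values shown sit. The compounds shown leave open whether any group at this place changes the result in this assay.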